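The source may hold more compounds than are shown below. What is called first, only, known or untested is meant among the compounds shown, and "the series" means these compounds.

Measured so far:
compound 1 `Cc1nn(-c2ncnc3nc[nH]c23)c2c1C(OC1CCCC1)CC(=O)N2` gives 2 nM
compound 2 `Cc1nn(-c2ncnc3nc[nH]c23)c2c1C(C(=O)N(C)c1nccs1)CC(=O)N2` gives 18 nM
compound 3 `Cc1nn(-c2ncnc3nc[nH]c23)c2c1C(C(=O)N(C)c1ccccc1)CC(=O)N2` gives 32 nM

These three share one core and differ only in the group on a saturated ring carbon. In a functional assay on HEK293 cells for agonist activity at G-protein coupled receptor 39 (Homo sapiens), read by scintillation proximity assay and inositol phosphate accumulation, with a stated time of 75 min, in the presence of a further agent that is not named here (a higher number here means that more compound is needed for the effect, a lower number that less compound is needed), compound 3 has the highest of the three numbers. Its nearest neighbour is compound 2, which differs only in having a 1,3-thiazol-2-yl in place of the phenyl on the amide-type nitrogen, and that step, a 1.8-fold higher number from compound 2 to compound 3 (0.25 log units; within the scatter), is within the scatter. The far end is compound 1, with cyclopentyloxy on the saturated ring carbon; the step of a 16-fold higher number from compound 1 to compound 3 (1.20 log units; beyond the scatter) shows that swapping that ether for the methyl(phenyl)carbamoyl costs a large amount.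

Compound 4 `Cc1nn(-c2ncnc3nc[nH]c23)c2c1C(OCC(C)C)CC(=O)N2` is not yet measured. It differs from compound 3 as follows: isobutoxy in place of methyl(phenyl)carbamoyl on a saturated ring carbon. This change returns to an ether at the same position, like compound 1, though isobutoxy carries no ring. The step of a 16-fold higher number from compound 1 to compound 3 (1.20 log units; beyond the scatter) is the one that bears on it, in the reverse direction; a sizeable drop in the number, beyond the scatter, is therefore expected in this assay, as an 8.0-fold lower number from compound 3 to compound 4 (0.90 log units; beyond the scatter). Compound 4 is expected to give about 4 nM, estimated between 1.5 nM and 12 nM.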

Compound 4, half-maximal effective concentration: 4 nM
Compound 4: middle estimate and measured number agree at the digits printed, within the range that was stated.
By their numbers in this assay, from the lowest: compounds 1 and 4 (each within the scatter of the next); then compounds 2 and 3 (each within the scatter of the next).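

With a second ether at this position, the low numbers in this assay are no longer tied to a single group: isobutoxy in place of the amides gives an 8.0-fold lower number from compound 3 to compound 4 (0.90 log units; beyond the scatter) and a 4.5-fold lower number from compound 2 to compound 4 (0.65 log units; beyond the scatter). The ring of the cyclopentyl group is also not needed to keep the number low, since an open-chain isobutyl on the same oxygen gives a 2.0-fold higher number from compound 1 to compound 4 (0.30 log units; within the scatter). No measurement is available here to explain why the two ethers and the two amides differ.

The compounds shown leave open whether the ether oxygen itself matters, which a plain isobutyl on the saturated ring carbon would test. They also leave open how far the chain can vary, from a short methoxy to a longer hexyloxy, and whether a hydroxyl or an amine at this carbon would fit the same trend.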